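A few compounds are considered here, and "the series" means these few. Any claim that something is new, unique, unknown or untested is made for them only; others in the source may bear on it.

Measured so far:
- compound 1 `CNC[C@@H]1CCN(c2cc3c(cc2F)c(=O)c(C(=O)O)cn3Cc2ccc(-n3cccn3)cc2)C1` — in an assay on isolated protein for inhibition of DNA topoisomerase 1 (Homo sapiens), with a stated time of 15 min (on this read-out lower numbers stand for stronger inhibition and higher numbers for weaker inhibition), compound 1 gives > 200000 nM, which is a limit of the assay, not a number.
- compound 2 `O=C(O)c1cn(Cc2ccc(-n3cccn3)cc2)c2cc(N3CC4CNCC4C3)c(F)cc2c1=O` — in this assay compound 2 gives 173000 nM.

Compound 2 holds the only number shown in this assay; the other value is a limit. Among the measured compounds shown here, the single measured step, an at least 1.1-fold lower number from compound 1 to compound 2 (0.06 log units; that floor lies within the scatter), is bounded by the limit of > 200000 nM in this assay, at which 1 of the 2 values shown sits, and lies within the scatter, so it shows no change that can be relied on.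

Compound 3 `NC[C@@H]1CCN(c2cc3c(cc2F)c(=O)c(C(=O)O)cn3Cc2ccc(-n3cccn3)cc2)C1` differs from compound 2 by a group of 7 heavy atoms (5 carbon, 2 nitrogen; one five-membered non-aromatic ring with 1 hetero atom) in place of a group of 8 heavy atoms (6 carbon, 2 nitrogen; 2 five-membered non-aromatic rings with 1 hetero atom each), on an aromatic carbon. The measured step concerns the same position on the same core, with groups of closely matched size, and it produced no movement beyond the scatter. On that basis the step from compound 2 to compound 3 in this assay is expected to be a 1.2-fold higher number from compound 2 to compound 3 (0.06 log units; within the scatter), with a fair chance that only a limit is returned. Compound 3 is therefore estimated at 200000 nM, with a range of 80000 nM to 500000 nM.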

Compound 3, half-maximal inhibitory concentration: 91600 nM
Estimate against measurement, compound 3: 2.2-fold (0.34 log units) above; the range from low to high includes it.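

Among the compounds shown here, on the 3-(aminomethyl)pyrrolidin-1-yl group, hydrogen in place of methyl on the amine nitrogen gives an at least 2.1-fold lower number from compound 1 to compound 3 (0.33 log units; beyond the scatter) in this assay, the only step here that clears the scatter. Going by these compounds, compound 1 stands at a limit and not a number, so this step is a floor and its full size stays unknown: the limit of > 200000 nM in this assay, at which 1 of the 3 values shown sits. Replacing the group with two five-membered rings on the aromatic carbon by the 3-(aminomethyl)pyrrolidin-1-yl group gives a 1.9-fold lower number from compound 2 to compound 3 (0.28 log units; within the scatter), so the amine groups of compound 2 and compound 3 cannot be told apart at this position.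

On these data alone, whether the gain from losing the methyl carries over to other amines at this position remains open. A piperazine or a longer aminoalkyl chain on the same aromatic carbon could test this.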